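A few compounds are considered here, and "the series" means these few. Any claim that something is new, unique, unknown or untested is made for them only; others in the source may bear on it.

Compound 1 `O=C(O)c1ccccc1-c1ccc(CCc2ncc(Cc3ccccc3Cl)[nH]2)cc1` gives 22 nM in an in vitro functional assay on cells for agonist activity at Bombesin receptor subtype-3 (Mus musculus), read by luminescence and calcium flux (a lower number here means that less compound is needed, a higher number that more compound is needed for the effect), the lower of the two numbers recorded so far; compound 2 `CCCCc1cnc(/C=C/c2ccc(-c3ccccc3C(=O)O)cc2)[nH]1` gives 10000 nM in this assay, a gap well beyond the scatter. Compound 3 `O=C(O)c1ccccc1-c1ccc(CCc2ncc(Cc3ccccc3)[nH]2)cc1` differs from compound 1 in one place: hydrogen in place of chloro on an aromatic carbon. Going by the values given here, no measured pair shows this change, so its effect is open. A modest loss is expected, the step from compound 1 to compound 3 estimated at a 2.7-fold higher number from compound 1 to compound 3 (0.44 log units; beyond the scatter), though a result within the scatter would not surprise. Compound 3 is therefore expected to give about 60 nM, with a range of 20 nM to 200 nM.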

Compound 3, half-maximal effective concentration: 11 nM
The estimate for compound 3 lay 5.5-fold (0.74 log units) above the measured number; the whole stated range lies above it.
By their numbers in this assay, from the lowest: compounds 3 and 1 (each within the scatter of the next); then compound 2.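

Hydrogen in place of chloro on this aromatic carbon gives a 2.0-fold lower number from compound 1 to compound 3 (0.30 log units; within the scatter) in this assay. The chloro of the 2-chlorobenzyl group is therefore not required here, and the plain benzyl group of compound 3 serves as well within the scatter. No measurement at hand bears on this result.

Still open, on these data alone, is whether a methoxy, a trifluoromethyl or an amine on this same aromatic carbon would leave the number unchanged. Also open, as far as these compounds go, is how chloro behaves on the other carbons of this ring.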